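Two cores, one ring swap, one expected loss of potency

The source may hold more compounds than are shown below. What is called first, only, known or untested is meant among the compounds shown, and "the series" means these compounds.

Measured so far in a functional assay on SGC-7901 cells (Homo sapiens) for antiproliferative activity, read by MTT assay, with a stated time of 24 h; on this read-out higher numbers stand for weaker inhibition and lower numbers for stronger inhibition:
- compound 1 `O=C(NNC(=O)c1cccc(NS(=O)(=O)c2cnc(O)nc2O)c1)c1cccc(Cl)c1` gives 7310 nM
- compound 2 `O=C(NNC(=O)c1ccccc1F)c1cccc(NS(=O)(=O)c2cnc(O)nc2O)c1` gives a limit of the assay, > 20000 nM
- compound 3 `O=C(NNC(=O)c1ccccc1NS(=O)(=O)c1cnc(O)nc1O)c1cccc(Cl)c1` gives 1820 nM

Compound 1 and compound 2 share a core and differ in one place (2-fluorophenyl in place of 3-chlorophenyl on a carbonyl carbon). The step of an at least 2.7-fold higher number from compound 1 to compound 2 (0.43 log units; beyond the scatter) is read against a limit, since the value of compound 2 is an assay limit (the limit of > 20000 nM in this assay, at which 1 of the 3 values shown sits); the true step may be larger than the floor it sets.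

Compound 3 has the same atoms as compound 1 joined differently; the difference between the two cores is not broken down here. In this assay compound 3 gives the lowest number of the two numbers measured, with compound 1 standing a clear step higher.

Compound 4 `O=C(NNC(=O)c1ccccc1NS(=O)(=O)c1cnc(O)nc1O)c1ccccc1F` has not been measured. It stands to compound 3 as compound 2 stands to compound 1 (2-fluorophenyl in place of 3-chlorophenyl on a carbonyl carbon); the place of the change is described in the same words for both pairs, so this is the same change on a different core. For compound 4 in this assay a weakening step of the same kind is expected, a 4.4-fold higher number from compound 3 to compound 4 (0.64 log units; beyond the scatter), resting on the step of an at least 2.7-fold higher number from compound 1 to compound 2 (0.43 log units; beyond the scatter) seen on the other core, with the caution that one measured example cannot fix its size. Compound 4 is expected to give about 8000 nM, within a range from 3000 nM to 22000 nM.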

Compound 4, half-maximal inhibitory concentration: > 20000 nM
Compound 4 ended at the assay's limit (the forecaster's own chance of this, stated with the estimate: 25%); middle value at least 2.5-fold (0.39 log units) from the limit.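

In this assay, putting 2-fluorophenyl in place of 3-chlorophenyl on a carbonyl carbon also weakens the result on the second core, with an at least 10-fold higher number from compound 3 to compound 4 (1.04 log units; beyond the scatter). Compound 4 gives > 20000 nM, which is a limit of the assay and not a number, and it is not alone there: the limit of > 20000 nM in this assay, at which 2 of the 4 values shown sit. So in this series the direction of the change carries over from one core to the other, but two cores cannot show that it holds on any further core, and the size of the loss stays unsettled, since neither step has a measured end point: the same change on two cores in this assay, an at least 2.7-fold higher number (0.43 log units; beyond the scatter) from compound 1 to compound 2 and an at least 10-fold higher number (1.04 log units; beyond the scatter) from compound 3 to compound 4; the limit leaves it open whether they differ.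

The move from 3-chlorophenyl to 2-fluorophenyl alters both the halogen and where it sits on the ring, and no pair of compounds shown separates those two parts of the change. Also open, as far as these compounds go, is how either core would respond if this carbonyl carbon carried a plain phenyl ring with no halogen, or a phenyl ring bearing an amine or a carboxylic acid.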